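The source may report more compounds than this note shows. Statements on the series, on what has been measured and on what is new or still open speak of the compounds shown alone.

Measured so far in a functional assay on SNB-75 cells (Homo sapiens) for inhibition, read by sulforhodamine B assay, with a stated time of 48 h; on this read-out higher numbers stand for weaker inhibition of growth and lower numbers for stronger inhibition of growth:
compound 1 `COc1cc(-c2nn(-c3cccc(NC(=O)Nc4cccc(C(F)(F)F)c4)c3)cc2-c2ccncc2)ccc1Cl` gives 1160 nM;
compound 2 `COc1cc(-c2nn(-c3cccc(NC(=O)Nc4ccc(Cl)c(C(F)(F)F)c4)c3)cc2-c2ccncc2)ccc1Cl` gives 1280 nM.

Compound 2 is the higher of these two numbers, but the step of a 1.1-fold higher number from compound 1 to compound 2 (0.04 log units; within the scatter) lies within the scatter, so the two compounds cannot be told apart. Compound 3 `COc1cc(-c2nn(-c3cccc(NC(=O)c4ccccc4)c3)cc2-c2ccncc2)ccc1Cl` differs from compound 2 by phenyl in place of (4-chloro-3-(trifluoromethyl)phenyl)amino on a carbonyl carbon. Among the compounds with values here, the only measured step alters a substituent on that same outer ring and was within the scatter; it does not cover removing the attached nitrogen altogether, so the expectation rests on no direct precedent. The expected step is a 2.7-fold higher number from compound 2 to compound 3 (0.44 log units; beyond the scatter), towards weaker inhibition. Compound 3 is estimated at 3500 nM, in the range 900 nM to 14000 nM.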

Compound 3, concentration for 50% growth inhibition: 575 nM
Compound 3: middle estimate off by 6.1-fold (0.78 log units), on the high side; measured number outside the range, below it.
By their numbers in this assay, from the lowest: compounds 3, 1 and 2 (each within the scatter of the next, the first and the last beyond it).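

Swapping the whole (4-chloro-3-(trifluoromethyl)phenyl)amino group for phenyl on the carbonyl carbon gives a 2.2-fold lower number from compound 2 to compound 3 (0.35 log units; beyond the scatter) in this assay, so that larger group, with its hydrogen-bond donor, is not required for growth inhibition here. Swapping the (3-(trifluoromethyl)phenyl)amino group of compound 1 the same way gives a 2.0-fold lower number from compound 1 to compound 3 (0.30 log units; within the scatter), which leaves those two compounds indistinguishable. No measurement shown here explains the change.

The compounds shown leave open how a smaller group on that carbonyl carbon, such as methyl, would compare. The same holds for a phenyl carrying a carboxylic acid.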